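Pyrimidinyl for Fluorophenyl on the Cyclopropane of a Biphenyl Amide

The source may hold more compounds than are shown below. What is called first, only, known or untested is meant among the compounds shown, and "the series" means these compounds.

Compound 1 `CC(C)CCCN(C(=O)[C@@H]1C[C@H]1c1ccccc1)c1ccc(-c2ccccc2)cc1`: in a functional assay for agonist activity at G protein-coupled receptor 88 (Homo sapiens), read by HTRF and cAMP accumulation (a higher number here means that more compound is needed for the effect, a lower number that less compound is needed), compound 1 gives > 100 nM, which is a limit of the assay and not a number.
Compound 2 `CC[C@H](C)[C@H](N)CN(C(=O)[C@@H]1C[C@H]1c1cccc(F)c1)c1ccc(-c2ccccc2)cc1`: in this assay compound 2 gives 560 nM.

Going by the values given here, compound 2 thus holds the only number among the two values shown; the other entry is the limit of > 100 nM in this assay, at which 1 of the 2 values shown sits. Compound 3 `CC[C@H](C)[C@H](N)CN(C(=O)[C@@H]1C[C@H]1c1cncnc1)c1ccc(-c2ccccc2)cc1` differs from compound 2 in one place: pyrimidin-5-yl in place of 3-fluorophenyl on a saturated ring carbon. Among the compounds with values here, no measured pair isolates this change, so its effect can only be expected, not read off. The expectation is a step of a 2.7-fold higher number from compound 2 to compound 3 (0.43 log units; beyond the scatter) in this assay, towards a higher number and beyond the usual scatter, with a real chance that only a limit is returned. Compound 3 is therefore estimated at 1500 nM in this assay, within a range from 400 nM to 6000 nM.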

Compound 3, half-maximal effective concentration: 19000 nM
Compound 3: the middle estimate sits 13-fold (1.10 log units) below what was measured; measured number outside the range, above it.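

Going by these compounds alone, this is the first measured pair that isolates the group on this saturated ring carbon: in this assay, pyrimidin-5-yl in place of 3-fluorophenyl gives a 34-fold higher number from compound 2 to compound 3 (1.53 log units; beyond the scatter), so the step is large. With the rest of compound 2 unchanged, the position therefore clearly distinguishes between these two six-membered aromatic rings, one of carbon only and carrying fluorine, the other with 2 hetero atoms and 2 hydrogen-bond acceptors. Nothing measured here accounts for the size of this step.

On these data alone, it remains open whether the step follows from the ring nitrogens or from the loss of the fluorine, which a plain phenyl or a pyridin-3-yl at this position could help to separate. As far as these compounds go, it also remains open whether the same exchange would give a similar step with a different chain on the amide nitrogen, such as one without the amine.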